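The compounds below may be only part of what the source reports. "The series", "measured", "known", "first", "only" and "open" are said of these compounds alone.

Measured so far:
Compound 1 `CSc1nc(-c2ccc(S(N)(=O)=O)cc2)n(-c2ccc(Cl)cc2)n1` gives 32300 nM in a functional assay on B16-F10 cells (Mus musculus) for antiproliferative activity, read by MTT assay, with a stated time of 72 h; a lower number here means a stronger inhibitor, a higher number a weaker inhibitor.
Compound 2 `CC(=O)Oc1ccc(/C=C/C(=O)OCCSc2nc(-c3ccc(S(C)(=O)=O)cc3)n(-c3ccc(F)cc3)n2)cc1OC(C)=O` gives 14200 nM in this assay.

Of these two numbers, compound 2 holds the lower one; compound 1 stands higher by a gap beyond the usual scatter. Compound 3 `CC(=O)Oc1ccc(/C=C/C(=O)OCCSc2nc(-c3ccc(S(C)(=O)=O)cc3)n(-c3ccc(C(F)(F)F)cc3)n2)cc1OC(C)=O` differs from compound 2 by trifluoromethyl in place of fluoro on an aromatic carbon. No step of this kind has been measured among these compounds, so nothing here points to a direction, and a change no larger than the usual scatter seems the likeliest outcome. Compound 3 is therefore expected to come in near 12000 nM, with a plausible range from 5000 nM to 30000 nM. That corresponds to an expected step of a 1.2-fold lower number from compound 2 to compound 3 (0.07 log units; within the scatter) in this assay.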

Compound 3, half-maximal inhibitory concentration: 11500 nM
Compound 3: the middle estimate sits 1.0-fold (0.02 log units) above what was measured, within the range that was stated.
By their numbers in this assay, from the lowest: compounds 3 and 2 (each within the scatter of the next); then compound 1.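

In this assay, the change from 4-fluorophenyl to 4-(trifluoromethyl)phenyl gives the first single-place step among these compounds (a 1.2-fold lower number from compound 2 to compound 3 (0.09 log units; within the scatter)). At this aromatic carbon, para to a large group, going from one heavy atom to four thus leaves the number within the scatter. This one pair shows that this particular exchange does not separate the two compounds in this assay.

As far as these compounds go, whether an amine, a carboxylic acid or a longer chain at the same place would move the number stays open. No measurement at hand offers any explanation of this result.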